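The source may hold more compounds than are shown below. What is called first, only, known or untested is meant among the compounds shown, and "the series" means these compounds.

Compounds measured so far in a functional assay on HCT-116 cells (Homo sapiens) for inhibition, read by MTT assay, with a stated time of 2 days; a lower number here means a stronger inhibitor of growth, a higher number a weaker inhibitor of growth

Compound 1 `Nc1ccccc1NC(=O)CCCNCC(=O)Nc1ccc(Br)cc1` gives 55500 nM
Compound 2 `Cc1ccc(NC(=O)CNc2ccc(C(=O)Nc3ccccc3N)cc2)cc1` gives > 100000 nM (a limit of the assay, not a number)
Compound 3 `COc1ccc(NC(=O)CNc2ccc(C(=O)Nc3ccccc3N)cc2)cc1` gives 38000 nM

Compound 1 stands within the scatter of compound 3, and compound 2 offers no number for comparison. The change to compound 4 `COc1ccc(NC(=O)CNCCCC(=O)Nc2ccccc2N)cc1` is methoxy in place of bromo on an aromatic carbon and reads as methoxy in place of bromo on an aromatic carbon, para to a large group.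

Within the data shown here, the one measured step that brings in methoxy is an at least 2.6-fold lower number from compound 2 to compound 3 (0.42 log units; beyond the scatter) and it lies beyond the scatter. That step replaces methyl rather than bromo, on a core other than that of compound 1, and it bears only loosely on this change. Among the measured compounds shown here, no step starting from bromo has been measured. Compound 3, which carries the same 4-methoxyphenyl, gives 38000 nM within the scatter of compound 1. No step beyond the scatter is therefore expected in this assay in either direction.

The expected step is a 1.2-fold lower number from compound 1 to compound 4 (0.09 log units; within the scatter) and it stays within the scatter. For compound 4 the estimated value is 45000 nM with an expected range from 20000 nM to 100000 nM as the likely span.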

Compound 4, concentration for total growth inhibition: 44000 nM
Compound 4: the middle estimate sits 1.0-fold (0.01 log units) above what was measured; measured number inside the range.
By their numbers in this assay, from the lowest: compounds 3, 4 and 1 (each within the scatter of the next). At a limit, above all of these: compound 2.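

In this assay, going from 4-bromophenyl to 4-methoxyphenyl gives a 1.3-fold lower number from compound 1 to compound 4 (0.10 log units; within the scatter), so at this position, para to a large group, the two groups cannot be told apart. This is the only step shown that starts from bromo, and it stands on the core of compound 1 itself, so it no longer has to be inferred from a methyl change on a different core. On this core, one more heavy atom and one more hydrogen-bond acceptor come with no change beyond the scatter.

From the compounds shown here alone, whether an amine or a carboxylic acid at this position would move the number beyond the scatter remains open, as does the effect of a longer chain on this core. Compound 2 gives only a limit, not a number: the limit of > 100000 nM in this assay, at which 1 of the 4 values shown sits.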